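The source may hold more compounds than are shown below. What is called first, only, known or untested is meant among the compounds shown, and "the series" means these compounds.

The measured compounds:

Compound 1, `CCOc1ccccc1/C=C/c1ccc2cccc(O)c2n1`: in a physicochemical assay for lipophilicity, read by HPLC (on this read-out higher numbers stand for higher lipophilicity and lower numbers for lower lipophilicity), compound 1 gives 4.55.
Compound 2, `Oc1ccccc1/C=C/c1ccc2cccc(O)c2n1`: in this assay compound 2 gives 3.95.
Compound 3, `Oc1ccc(/C=C/c2ccc3c(Cl)cc(Cl)c(O)c3n2)cc1`: in this assay compound 3 gives 5.07.

Compound 2 and compound 1 differ in one place, (ethyl in place of hydrogen on an oxygen on an aromatic ring), and that change brings a number 0.60 log units higher from compound 2 to compound 1 (beyond the scatter). Compound 3 stands highest of the three measured numbers, beyond the scatter of both others, and the difference between its core and the core of compound 2 is not broken down here; the two values alone show that compound 3 sits well above compound 2.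

Compound 4, `CCOc1ccc(/C=C/c2ccc3c(Cl)cc(Cl)c(O)c3n2)cc1`, has not yet been measured in this assay. For the measured compounds named here, it differs from compound 3 in one place, (ethyl in place of hydrogen on an oxygen on an aromatic ring), which is the same change as the one from compound 2 to compound 1, made on the same kind of place. Only one measured instance of this change exists among these compounds, so the expectation rests on a single step. For compound 4 the expected step is a number 0.60 log units higher from compound 3 to compound 4 (beyond the scatter), because the same change gave a number 0.60 log units higher from compound 2 to compound 1 (beyond the scatter). Compound 4 is therefore estimated at 5.67, with the likely range running from 5.3 to 6.05.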

Compound 4, partition coefficient: 5.67
Beside the measured number, compound 4's estimate shows no gap at the digits printed, and the stated range covers the measured number.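

In this assay the change of hydroxy to ethoxy brings a number 0.60 log units higher from compound 3 to compound 4 (beyond the scatter) and, on the other core, a number 0.60 log units higher from compound 2 to compound 1 (beyond the scatter) in the earlier pair, so in these two pairs the change carried from one core to the other with its step the same size and with no compound shown going against it. For the compounds shown here, this is still only two pairs on two cores that differ from each other in more than one place, so it does not show that the step would hold on any further core, and it cannot say which of the differences between these cores, if any, could alter the step. Nothing measured here accounts for the two steps matching in size.

The compounds shown leave open whether the step grows, holds or shrinks when the ethyl on that oxygen gives way to a longer chain such as butyl, or to a chain ending in an amine or a carboxylic acid. They also leave open whether the same change keeps its size on other cores, for instance with fluorine in place of chlorine on the core of compound 3.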